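Cytotoxicity series: a benzyl amide variant of compound 1

The compounds below may be only part of what the source reports. "The series", "measured", "known", "first", "only" and "open" are said of these compounds alone.

Compound 1 `COc1ccc2c(=O)c(/C=C/C(=O)Nc3ccccc3Cl)coc2c1` is the reference. For the measured compounds named here, in an ADME assay on HepG2 2.2.15 cells (Homo sapiens) for cytotoxicity, read by MTT assay, with stated times of 48 h and 9 days (on this read-out higher numbers stand for lower toxicity in this test and lower numbers for higher toxicity in this test), compound 1 gives 1010000 nM, the second highest of the three numbers known here. Compound 3 `COc1ccc2c(=O)c(/C=C/C(=O)Nc3ccccc3OC)coc2c1` gives 1050000 nM, and the step of a 1.0-fold higher number from compound 1 to compound 3 (0.02 log units; within the scatter) is within the scatter. Compound 2 `COc1ccc2c(=O)c(/C=C/C(=O)NCc3cccc(F)c3)coc2c1` gives 475000 nM, and the step of a 2.1-fold lower number from compound 1 to compound 2 (0.33 log units; beyond the scatter) is the only one beyond the scatter in this small set.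

Compound 4 `COc1ccc2c(=O)c(/C=C/C(=O)NCc3ccc(F)cc3F)coc2c1` is not yet measured. The change from compound 1 is 2,4-difluorobenzyl in place of 2-chlorophenyl on an amide-type nitrogen. Going by the values given here, the closest precedent is the move to a fluorinated benzyl amide in the step of a 2.1-fold lower number from compound 1 to compound 2 (0.33 log units; beyond the scatter), a modest drop in the number. The step of a 2.2-fold higher number from compound 2 to compound 3 (0.34 log units; beyond the scatter) shows the same shift in the reverse direction. Compound 4 carries the same type of change, so a step of similar size and direction is expected rather than none.

For compound 4 the estimated value in this assay is 550000 nM, with a range from 300000 nM to 1100000 nM. This estimate corresponds to an expected step of a 1.8-fold lower number from compound 1 to compound 4 (0.26 log units; within the scatter).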

Compound 4, half-maximal cytotoxic concentration: 79300 nM
Compound 4: the middle estimate sits 6.9-fold (0.84 log units) above what was measured, outside the stated range (below it).
By their numbers in this assay, from the lowest: compound 4; then compound 2; then compounds 1 and 3 (each within the scatter of the next).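

In this assay, for the compounds shown here, this place on the amide-type nitrogen can move the number much further than the earlier compounds showed, with a 13-fold lower number from compound 1 to compound 4 (1.11 log units; beyond the scatter) and a 13-fold lower number from compound 3 to compound 4 (1.12 log units; beyond the scatter) both large, against earlier steps that were modest or within the scatter. The benzyl amides do not read as one group: 2,4-difluorophenyl in place of 3-fluorophenyl on the saturated chain carbon gives a 6.0-fold lower number from compound 2 to compound 4 (0.78 log units; beyond the scatter) on its own, so the benzyl link alone does not set the number. Nothing available here explains this drop.

Open, on these data alone, is whether the drop follows the second fluorine or its placing, which an unsubstituted benzyl, a 2-fluorobenzyl or a 4-fluorobenzyl on the same nitrogen would help separate. Also open, as far as these compounds go, is how a benzyl carrying an amine or a carboxylic acid would read.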